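From 4-fluorophenyl to 3-iodophenyl on a shared core

A few compounds are considered here, and "the series" means these few. Any claim that something is new, unique, unknown or untested is made for them only; others in the source may bear on it.

Measured so far in a functional assay on MCF7 cells (Homo sapiens) for antiproliferative activity, read by MTT assay, with a stated time of 48 h; on this read-out higher numbers stand for weaker inhibition and lower numbers for stronger inhibition:
- Compound 1 `Oc1ccc2ccccc2c1C(Nc1nc2ccccc2s1)c1cn(-c2ccccc2)nc1-c1ccccc1`: 48900 nM
- Compound 2 `Oc1ccc2ccccc2c1C(Nc1nc2ccccc2s1)c1cn(-c2ccccc2)nc1-c1ccc(I)cc1`: 18900 nM
- Compound 3 `COc1ccc2nc(NC(c3cn(-c4ccccc4)nc3-c3ccc(F)cc3)c3c(O)ccc4ccccc34)sc2c1`: 16900 nM

Compound 3, at 16900 nM, lies within the scatter of compound 2, and compound 1 stands higher than compound 3, beyond the scatter. Compound 4 `COc1ccc2nc(NC(c3cn(-c4ccccc4)nc3-c3cccc(I)c3)c3c(O)ccc4ccccc34)sc2c1` differs from compound 3 in one place, where 3-iodophenyl takes the place of 4-fluorophenyl on an aromatic carbon of a five-membered aromatic ring with 2 nitrogen: 3-iodophenyl in place of 4-fluorophenyl on an aromatic carbon.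

Within the data shown here, only one measured step bears on this. Iodo in place of hydrogen on an aromatic carbon gave a 2.6-fold lower number from compound 1 to compound 2 (0.41 log units; beyond the scatter), a modest change. Among the measured compounds shown here, that pair differs from compound 3 elsewhere, however, and no measured step compares fluorine with iodine or tests where the iodine sits. A slightly lower number in this assay is therefore expected, but nothing beyond the scatter, an estimated 1.2-fold lower number from compound 3 to compound 4 (0.08 log units; within the scatter) in all. Compound 4 is expected at 14000 nM with 6500 nM to 32000 nM as its estimated range.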

Compound 4, half-maximal inhibitory concentration: 20000 nM
Beside the measured number, compound 4's estimate is 1.4-fold (0.15 log units) below it, within the range that was stated.
By their numbers in this assay, from the lowest: compounds 3, 2 and 4 (each within the scatter of the next); then compound 1.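

In this assay, the exchange of 4-fluorophenyl for 3-iodophenyl gave a 1.2-fold higher number from compound 3 to compound 4 (0.07 log units; within the scatter), so on the core of compound 3 this position takes either group with no difference that can be told from the scatter. The earlier step, a 2.6-fold lower number from compound 1 to compound 2 (0.41 log units; beyond the scatter), showed iodine only in place of hydrogen on a different core, whereas this step shows that an iodine-bearing phenyl group offers no measurable advantage here over a fluorine-bearing one. No measurement presented here explains this result.

Because the halogen and its place on the ring change together in this step, the effect of each remains unseparated. From the compounds shown here alone, it also remains open whether an amine or a carboxylic acid on this phenyl ring would shift the number beyond the scatter.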